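From compound 2 to compound 3: an unreadable step

A few compounds are considered here, and "the series" means these few. Any claim that something is new, unique, unknown or untested is made for them only; others in the source may bear on it.

In an ADME assay on cells (Erythrocyte, Homo sapiens), read by spectrophotometry and hemolysis, with a stated time of 24 h (on this read-out higher numbers stand for weaker inhibition and lower numbers for stronger inhibition), compound 1 (`C=CCNC(=S)N/N=C\c1ccccc1OCc1ccc2no[n+]([O-])c2c1`) gives 139 uM. Compound 2 (`NC(=O)N/N=C\c1ccccc1OCc1ccc2no[n+]([O-])c2c1`) gives > 100 uM, which is a limit and not a number. Among the measured compounds shown here, the one measured step, a step that the limit leaves unreadable from compound 1 to compound 2, therefore has no size, and the limit of > 100 uM in this assay, at which 1 of the 2 values shown sits, is all that can be said of where compound 2 stands. Compound 3 (`C/C(=N/NC(=N)N)c1ccccc1OCc1ccc2no[n+]([O-])c2c1`) carries a new group on an aromatic carbon: a group of 7 heavy atoms (3 carbon, 4 nitrogen; no ring) in place of a group of 6 heavy atoms (2 carbon, 3 nitrogen, 1 oxygen; no ring), on an aromatic carbon. For the measured compounds named here, no measured step of known size bears on this change, so the only anchor is compound 1 at 139 uM. The expected step, a step that the limit leaves unreadable from compound 2 to compound 3, is estimated to stay within the usual scatter, with no direction expected. The estimate for compound 3 is 120 uM, with an expected range of 40 uM to 300 uM.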

Compound 3, concentration for 50% inhibition: > 200 uM
Compound 3: only a limit was reported (the forecaster's own chance of this, stated with the estimate: 50%); middle value at least 1.6-fold (0.22 log units) from the limit.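

Compound 3 is reported only as a limit, not a number: the limit of > 200 uM in this assay, at which 1 of the 3 values shown sits. Among the compounds shown here, the one readable step in this assay is an at least 1.4-fold higher number from compound 1 to compound 3 (0.15 log units; that floor lies within the scatter), so this floor does not separate the group of 7 heavy atoms, on an aromatic carbon ortho to a large group, from the group that stands in its place in compound 1 beyond the scatter. The step involving compound 2 cannot be read, since both of its ends are limits.

Still open, from the compounds shown here alone, is how far the true value of compound 3 lies from its limit. Also open, going by these compounds, is whether an amine or a carboxylic acid in place of these groups would give a number rather than a limit.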